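A Methyl Group Added to a Five-Ring Fused Core

This account rests on a few compounds, and the source may have more. Where it says the series, first, only, none or still open, it means among the compounds named here.

Of the compounds shown here, three have been measured in a functional assay on HBL-100 cells (Homo sapiens) for inhibition, read by sulforhodamine B assay, with a stated time of 48 h; on this read-out higher numbers stand for weaker inhibition of growth and lower numbers for stronger inhibition of growth. Compound 1, with the structure `COC(=O)[C@@]1(C)CCC=C2[C@@H]1CC[C@@H](C)[C@]2(C)Cc1c[nH]c2c(C)cccc12`, gives 8000 nM in this assay. Compound 2, with the structure `COC(=O)[C@@]1(C)CCC=C2[C@@H]1CC[C@@H](C)[C@]2(C)Cc1c(C)[nH]c2c(C)cccc12`, differs from compound 1 by a single change, (methyl in place of hydrogen on an aromatic carbon), and in this assay compound 2 gives 16000 nM. That change produced a 2.0-fold higher number from compound 1 to compound 2 (0.30 log units; within the scatter), so the two numbers cannot be told apart with confidence.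

Compound 3, with the structure `COC(=O)[C@@]1(C)CC[C@@H]2C3=C1CC[C@@H](C)[C@]3(C)C[C@@H]1c3ccccc3N[C@H]21`, has a different core; how it differs from the core of compound 1 is not broken down here. In this assay compound 3 gives 78000 nM, the highest of the three numbers and beyond the scatter from both compound 1 and compound 2.

Compound 4, with the structure `COC(=O)[C@@]1(C)CC[C@@H]2C3=C1CC[C@@H](C)[C@]3(C)C[C@@H]1c3cc(C)ccc3N[C@H]21`, is not yet measured. It carries the change (methyl in place of hydrogen on an aromatic carbon). Among the measured compounds shown here, this is the same kind of change as the one from compound 1 to compound 2, but not the same: there the methyl entered a five-membered aromatic ring with one nitrogen, next to the ring nitrogen and next to the ring atom that bears a large group, whereas here it enters a six-membered aromatic ring of carbon only, meta to a fused ring and para to a fused ring. Resting on the step from compound 1 to compound 2, which was a 2.0-fold higher number from compound 1 to compound 2 (0.30 log units; within the scatter), a small step is expected for compound 4, namely a 1.3-fold higher number from compound 3 to compound 4 (0.11 log units; within the scatter). The estimate for compound 4 is therefore 100000 nM, expected to lie between 40000 nM and 250000 nM.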

Compound 4, concentration for 50% growth inhibition: 15000 nM
For compound 4 the middle estimate is 6.7-fold (0.82 log units) above the measured one, and the stated range ends above it.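

On the core of compound 3, putting a methyl in place of hydrogen on an aromatic carbon gave a 5.2-fold lower number from compound 3 to compound 4 (0.72 log units; beyond the scatter) in this assay, so here the added methyl goes with stronger inhibition of growth. Set beside the earlier step, this result shows that the effect of this kind of change did not carry from one core to the other, and a step read on one core would have been a poor guide to the step on the other: the same change on two cores in this assay, a 2.0-fold higher number (0.30 log units; within the scatter) from compound 1 to compound 2 and a 5.2-fold lower number (0.72 log units; beyond the scatter) from compound 3 to compound 4, 10-fold (1.02 log units) apart, beyond the scatter of two such steps What this does not show is why the two steps differ, for the methyl entered a different kind of ring in each case, so the core as a whole cannot be separated from the ring that took the methyl, and each core offers only a single step.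

The compounds shown leave open whether the gain on the core of compound 3 is particular to methyl or would also appear with a different group on the same aromatic carbon, such as an ethyl chain, a methoxy group or a chlorine atom. They also leave open how a methyl would act on the other carbons of that six-membered aromatic ring.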